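From compound 3 to compound 4: lengthening the chain

This account rests on a few compounds, and the source may have more. Where it says the series, first, only, none or still open, it means among the compounds named here.

Going by the values given here, in a functional assay on PC-3 cells (Homo sapiens) for inhibition, read by MTT assay, with stated times of 18 h and 4 h (on this read-out higher numbers stand for weaker inhibition and lower numbers for stronger inhibition), compound 1 `CCCCCCCCCCCCCCCCOP(=O)(O)OCCSC(=S)N1CCCCCC1` gives the only true number, 32100 nM. Compound 2 `CCCCCCCCOP(=O)(O)OCCSC(=S)N1CCCC1` reads > 100000 nM, which is a limit. Compound 3 `CCCOP(=O)(O)OCCSC(=S)N1CCCCC1` reads > 100000 nM, also a limit. Compound 3 thus stands at the limit of > 100000 nM in this assay, at which 2 of the 3 values shown sit. Compound 4 `CCCCCCCCCCOP(=O)(O)OCCSC(=S)N1CCCCC1` carries heptyl in place of hydrogen on a saturated chain carbon, three bonds along the chain from an oxygen on an unsaturated carbon. The expectation rests on compound 1 at 32100 nM, which differs from compound 3 in more than one place. A modest gain toward stronger inhibition in this assay is expected, an estimated at least 1.8-fold lower number from compound 3 to compound 4 (0.25 log units; that floor lies within the scatter). For compound 4, the estimate is 55000 nM, with an expected range of 20000 nM to 100000 nM.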

Compound 4, half-maximal inhibitory concentration: 62500 nM
Compound 4: middle estimate off by 1.1-fold (0.06 log units), on the low side, and the stated range covers the measured number.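

Going by these compounds alone, compound 4 gives the first one-place comparison: with the rest of the core unchanged, heptyl in place of hydrogen at this chain carbon turns a limit into a true number in this assay, a change of an at least 1.6-fold lower number from compound 3 to compound 4 (0.20 log units; that floor lies within the scatter). The step can be stated only as a floor, because compound 3 has only a limit: the limit of > 100000 nM in this assay, at which 2 of the 4 values shown sit.

As far as these compounds go, whether a longer chain, or a chain bearing an amine, would lower the number further remains open. From the compounds shown here alone, the full size of this step also remains open.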